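The source may report more compounds than this note shows. Statements on the series, on what has been measured and on what is new or still open speak of the compounds shown alone.

Working notes on a series sharing one core.

Compound 3 `CCCOCC(=O)Nc1cc2nc(C3CCCCC3)[nH]c2cc1N(C)C` carries a propoxymethyl group on the carbonyl carbon and a dimethylamino group on the aromatic carbon. In an ADME assay on Vero cells (Chlorocebus sabaeus) for cytotoxicity, read by resazurin assay, with a stated time of 3 days (on this read-out lower numbers stand for stronger inhibition and higher numbers for weaker inhibition), compound 3 gives only a limit of the assay, < 50 ug/mL. Compound 1 `CCOCCOC(=O)Nc1cc2nc(C3CCCCC3)[nH]c2cc1N(C)C` differs from compound 3 by 2-ethoxyethoxy in place of propoxymethyl on a carbonyl carbon. In this assay compound 1 likewise gives only a limit, > 100 ug/mL. The step is an at least 2.0-fold higher number from compound 3 to compound 1 (0.30 log units; that floor lies within the scatter); its ends sit at the limit of < 50 ug/mL in this assay, at which 1 of the 3 values shown sits, and at the limit of > 100 ug/mL in this assay, at which 2 of the 3 values shown sit, so only a floor for its size is known.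

Compound 2 `CCCOCC(=O)Nc1cc2nc(C3CCCCC3)[nH]c2cc1N1CCCC1` differs from compound 3 in the core by pyrrolidin-1-yl in place of dimethylamino on an aromatic carbon. In this assay compound 2 gives a limit, > 100 ug/mL. The step is an at least 2.0-fold lower number from compound 2 to compound 3 (0.30 log units; that floor lies within the scatter), again with both ends at limits.

Compound 4 `CCOCCOC(=O)Nc1cc2nc(C3CCCCC3)[nH]c2cc1N1CCCC1` is not yet measured in this assay. It differs from compound 2 by 2-ethoxyethoxy in place of propoxymethyl on a carbonyl carbon. This is the same change as that from compound 3 to compound 1, with the place described in identical words, but on the core of compound 2. The earlier step, an at least 2.0-fold higher number from compound 3 to compound 1 (0.30 log units; that floor lies within the scatter), ran toward weaker inhibition and already reached the upper limit. Compound 2 starts at > 100 ug/mL, so compound 4 is expected to show a step that the limit leaves unreadable from compound 2 to compound 4, most likely again reported only as a limit. For compound 4 the estimated value in this assay is 150 ug/mL, with an expected range from 70 ug/mL to 400 ug/mL.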

Compound 4, half-maximal inhibitory concentration: > 100 ug/mL
Compound 4 gave a limit, no number; the forecaster's own chance of this, stated with the estimate: 80%; the middle value lies beyond the limit too.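

In this assay compound 4 gives > 100 ug/mL, which is a limit of the assay and not a number. Compound 1 and compound 2 also sit at that limit, so neither step to compound 4 can be read. The compounds shown leave open how far the true values of compound 1, compound 2 and compound 4 lie beyond the limit, and whether 2-ethoxyethoxy in place of propoxymethyl changes the read-out when pyrrolidin-1-yl is present.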